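Urea to amide on a pyrazole scaffold: an expectation

The source may hold more compounds than are shown below. What is called first, only, known or untested is meant among the compounds shown, and "the series" means these compounds.

Compound 1 `COc1cc(Cl)cc(-c2nn(-c3cccc(NC(=O)Nc4ccc(Cl)c(C(F)(F)F)c4)c3)cc2-c2ccncc2)c1` gives 83% in a functional assay on UACC-257 cells (Homo sapiens) for inhibition, read by sulforhodamine B assay, with a stated time of 48 h, tested at 1 uM; on this read-out lower numbers stand for a stronger effect and higher numbers for a weaker effect at the one concentration tested. Compound 2 `COc1cc(Cl)cc(-c2nn(-c3cccc(NC(=O)Nc4ccc(Cl)c(Cl)c4)c3)cc2-c2ccncc2)c1` gives 80% in this assay. Compound 3 `COc1cc(Cl)cc(-c2nn(-c3cccc(NC(=O)Nc4cccc(C(F)(F)F)c4)c3)cc2-c2ccncc2)c1` gives 78% in this assay.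

The three numbers sit close together. Compound 3 holds the lowest of them, yet the step of a number 2 percentage points lower from compound 2 to compound 3 (within the scatter) and the step of a number 5 percentage points lower from compound 1 to compound 3 (within the scatter) both fall within the scatter, as does the step of a number 3 percentage points lower from compound 1 to compound 2 (within the scatter). Going by the values given here, nothing among the measured compounds, then, separates them beyond repeat-to-repeat noise.

Compound 4 `COc1cc(Cl)cc(-c2nn(-c3cccc(NC(=O)c4cccc(C(F)(F)F)c4)c3)cc2-c2ccncc2)c1` differs from compound 3 by 3-(trifluoromethyl)phenyl in place of (3-(trifluoromethyl)phenyl)amino on a carbonyl carbon. Among the compounds with values here, none of the measured steps touches this position: each of them alters only the substituents on the distal phenyl ring or swaps one such ring for another, and each was within the scatter. The change to compound 4 is therefore untested by the data at hand.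

Within the data shown here, with no step bearing on it, the expectation for compound 4 rests on the narrow spread of the measured compounds, and the step of a number 2 percentage points higher from compound 3 to compound 4 (within the scatter) is estimated to be small. Compound 4 is expected to give about 80% in this assay, within a range of 62% to 96%.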

Compound 4, a percentage reported as activity, at one concentration (the size of the read-out at that concentration, not a potency): 92%
For compound 4 the middle estimate is 12 percentage points below the measured one, within the range that was stated.
By their numbers in this assay, from the lowest: compounds 3, 2, 1 and 4 (each within the scatter of the next, the first and the last beyond it).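

Unlike the earlier changes on the distal ring, the change on the carbonyl carbon, where 3-(trifluoromethyl)phenyl enters in place of an arylamino group, can shift the read-out in this assay beyond the scatter: a number 14 percentage points higher from compound 3 to compound 4 (beyond the scatter), the direct comparison with the same aryl group, and a number 12 percentage points higher from compound 2 to compound 4 (beyond the scatter), which also alters the ring substituents. The shift is not seen against every urea, since compound 1 goes against it, with a number 9 percentage points higher from compound 1 to compound 4 (within the scatter). No measurement shown explains the shift at this position.

The compounds shown leave open whether the amino nitrogen itself matters or whether an ether oxygen or a methylene group at that place would give the same number. They also leave open how the amide link behaves with a 3,4-dichlorophenyl group on the carbonyl carbon.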